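The compounds below may be only part of what the source reports. "The series", "measured", "known", "first", "only" and "open" are said of these compounds alone.

Measured compounds:
- compound 1, `Cn1cc(/C=C2/C(=O)Nc3ccccc32)c2cc(Nc3nccc(-c4ccc(F)cc4)n3)ccc21`: 168000 nM
- compound 2, `Cn1cc(/C=C2/C(=O)Nc3ccccc32)c2cc(Nc3nccc(-c4ccc(Cl)cc4Cl)n3)ccc21`: "not determined" (no result reported)

Compound 1 was tested in an ADME assay on RWPE-1 cells (Homo sapiens) for cytotoxicity, read by MTT assay, with a stated time of 48 h (a lower number here means a stronger inhibitor, a higher number a weaker inhibitor), and gave 168000 nM, a weak effect on these cells. Within the data shown here, compound 2 shares the same core and differs only in the ring attached to it, yet in this assay compound 2 gives "not determined" (no result reported), so where it stands cannot be told from the data; its position rests only on the one figure of compound 1.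

Compound 3, `Cn1cc(/C=C2/C(=O)Nc3ccccc32)c2cc(Nc3nccc(-c4cccs4)n3)ccc21`, is the untested member. Its change from compound 2 is thiophen-2-yl in place of 2,4-dichlorophenyl on an aromatic carbon, in words thiophen-2-yl in place of 2,4-dichlorophenyl on an aromatic carbon. Among the measured compounds shown here, no step between measured compounds is available to set a scale for this swap, so the expected shift in this assay is none beyond the usual scatter, in either direction.

Compound 3 is therefore expected to give about 150000 nM in this assay, most likely between 40000 nM and 500000 nM, because compound 1 with the same core gives 168000 nM and nothing in the data points away from that level.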

Compound 3, half-maximal inhibitory concentration: 64900 nM
Compound 3: the middle estimate sits 2.3-fold (0.36 log units) above what was measured; low and high end bracket the measured number.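

With the shared core held fixed, thiophen-2-yl in place of 4-fluorophenyl on this aromatic carbon gives a 2.6-fold lower number from compound 1 to compound 3 (0.41 log units; beyond the scatter) in this assay, which shows that the group here can move the number beyond the usual scatter, towards a modestly stronger effect on these cells. The swap from 2,4-dichlorophenyl to thiophen-2-yl cannot be read, as compound 2 has no number, so this single pair is all that speaks for this position. Nothing in the data accounts for the step.

Open, from the compounds shown here alone, is what in the change matters: the five-membered ring in place of the six-membered one, the sulfur as the hetero atom, or the absence of fluorine, as the three differ together between these two compounds. Also open, going by these compounds, is how the number would respond to other groups on this carbon, such as an amine, a morpholine ring, a thiophen-3-yl ring or a phenyl ring carrying a carboxylic acid, and whether any such group would take the number further down or back up.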